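A few compounds are considered here, and "the series" means these few. Any claim that something is new, unique, unknown or untested is made for them only; others in the source may bear on it.

Measured compounds:
compound 1 `O=C(Nc1cccc(-n2cc(-c3ccncc3)c(-c3ccc(Cl)c(O)c3)n2)c1)Nc1cccc(C(F)(F)F)c1` – 11600 nM
compound 2 `COc1cc(-c2nn(-c3cccc(NC(=O)Nc4cc(C(F)(F)F)cc(C(F)(F)F)c4)c3)cc2-c2ccncc2)ccc1Cl` – 1710 nM
compound 3 `COc1cc(-c2nn(-c3cccc(NC(=O)c4cccc(C(F)(F)F)c4)c3)cc2-c2ccncc2)ccc1Cl` – 2300 nM

In a functional assay on SF-539 cells (Homo sapiens) for inhibition, read by sulforhodamine B assay, with a stated time of 48 h (a higher number here means a weaker inhibitor of growth, a lower number a stronger inhibitor of growth), compound 3 gives 2300 nM, the second highest of the three numbers. Its nearest neighbour is compound 2, whose value lies within the scatter of compound 3, so no order between these two can be read. Compound 1 stands furthest away, with a higher number than compound 3, and that gap lies beyond the scatter; compound 1 differs from compound 3 in more than one place, so only the two values themselves can be compared.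

Compound 4 `COc1cc(-c2nn(-c3cccc(NC(=O)Nc4ccc(Cl)c(Cl)c4)c3)cc2-c2ccncc2)ccc1Cl` has not been measured in this assay. It is reached from compound 3 by one change: (3,4-dichlorophenyl)amino in place of 3-(trifluoromethyl)phenyl on a carbonyl carbon. The new compound therefore carries a urea linker, as compound 2 does, where compound 3 carries an amide. Compound 2 gives 1710 nM in this assay, within the scatter of compound 3, which suggests that exchanging amide for urea on this core moves the number little. Compound 1, also a urea, gives a higher number, but it also differs on the core.

The step from compound 3 to compound 4 is expected to stay within the scatter, a 1.0-fold lower number from compound 3 to compound 4 (0.02 log units; within the scatter). Compound 4 is estimated at 2200 nM, with a range from 800 nM to 6000 nM.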

Compound 4, concentration for total growth inhibition: 3080 nM
Estimate against measurement, compound 4: 1.4-fold (0.15 log units) below; low and high end bracket the measured number.
By their numbers in this assay, from the lowest: compounds 2, 3 and 4 (each within the scatter of the next); then compound 1.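

In this assay, among these compounds, (3,4-dichlorophenyl)amino in place of 3-(trifluoromethyl)phenyl on a carbonyl carbon gives a 1.3-fold higher number from compound 3 to compound 4 (0.13 log units; within the scatter), the first step that can be read at a single place. On the shared core, this position therefore accepts the amide-to-urea exchange, the extra hydrogen-bond donor and the replacement of trifluoromethyl by two chlorines, taken together, with no change that can be read in this growth read-out. No measured property bears on this result, so the data give no explanation for it.

Among the compounds shown here, the single step changes the linker and the ring substituents at once, so their separate contributions remain unresolved; they could be separated by pairing the urea with 3-(trifluoromethyl)phenyl and the amide with 3,4-dichlorophenyl on the shared core. The compounds shown also leave open whether this carbonyl carbon can carry a partner other than a substituted phenyl ring, such as a cyclohexyl group, a morpholine or a short chain ending in a carboxylic acid.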